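Shorter chain in place of vinyl: a cytotoxicity estimate

The compounds below may be only part of what the source reports. "The series", "measured", "known", "first", "only" and "open" are said of these compounds alone.

- Compound 1 `C=CCCCCC/C=C\[C@H](O)C#CC#CC1OC1C` gives 70600 nM
- Compound 2 `CCCCCCCCCC(O)C#CC#C[C@@H](O)[C@H](C)O` gives 39800 nM
- Compound 3 `C=CC(O)C#CC#C[C@@H](O)[C@H](C)O` gives 177000 nM

All three values come from an ADME assay on Hepa-1c1c7 cells (Mus musculus) for cytotoxicity; on this read-out lower numbers stand for stronger inhibition and higher numbers for weaker inhibition. Compound 3 has the highest number of the three, so it is the weakest inhibitor here. Compound 1 and compound 2 both sit lower, each by a gap beyond the usual scatter.

The next compound, compound 4 `CCCCCC(O)C#CC#C[C@@H](O)[C@H](C)O`, keeps the core of compound 3 and changes one group: pentyl in place of vinyl on a saturated chain carbon bound to an oxygen on a saturated carbon and a triple-bonded carbon. For the measured compounds named here, no measured pair isolates a change of this kind, so any expectation is indirect. Going by the values given here, compound 2, which also carries a saturated chain on that carbon, gives 39800 nM, and that is the only guide to the direction. A modest move towards a lower number, meaning stronger inhibition, therefore seems likely. The expected size is a 2.4-fold lower number from compound 3 to compound 4 (0.37 log units; beyond the scatter). The estimated value for compound 4 is 75000 nM, with an expected range from 35000 nM to 150000 nM.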

Compound 4, half-maximal inhibitory concentration: > 500000 nM
Compound 4 was reported as a limit (the forecaster's own chance of this, stated with the estimate: 5%); middle value at least 6.6-fold (0.82 log units) from the limit.
By their numbers in this assay, from the lowest: compounds 2 and 1 (each within the scatter of the next); then compound 3. At a limit, above all of these: compound 4.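

Replacing vinyl with pentyl on this carbon gives an at least 2.8-fold higher number from compound 3 to compound 4 (0.45 log units; beyond the scatter) in this assay, so placing a saturated chain here does not by itself lower the number. Adding butyl's worth of chain in the other direction matters far more, with an at least 12-fold higher number from compound 2 to compound 4 (1.09 log units; beyond the scatter), and the number therefore does not move one way with chain length: the pentyl compound sits above both the vinyl compound and the longer-chain compound. Compound 4 is reported only as a limit, so both steps give minimum sizes: the limit of > 500000 nM in this assay, at which 1 of the 4 values shown sits.

The compounds shown leave open how far compound 4 really lies from the others, and at what length between pentyl and the longer chain the number begins to fall. A heptyl chain, or a chain ending in an amine or a carboxylic acid, remains an open case at this position.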